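The source may hold more compounds than are shown below. What is called first, only, known or untested is meant among the compounds shown, and "the series" means these compounds.

Working notes on the series.

Compound 1 `CCC(COc1ccccc1)OC(=O)NCc1ccccc1` sits at a limit in an assay for inhibition of zeta-carotene desaturase, chloroplastic/chromoplastic (Capsicum annuum), using a Dixon plot, with a stated time of 8 h; a higher number here means a weaker inhibitor, a lower number a stronger inhibitor: compound 1 gives > 100000 nM, which is a limit of the assay and not a number. Compound 2 `CCC(COc1cccc(C#N)c1)OC(=O)NCc1ccccc1` carries cyano in place of hydrogen on an aromatic carbon; in this assay compound 2 also gives only a limit, > 100000 nM. Compound 3 `CCC(COc1cccc(Cl)c1Cl)OC(=O)NCc1ccccc1` carries 2,3-dichlorophenyl in place of phenyl on an oxygen on a saturated carbon; in this assay compound 3 likewise gives only a limit, > 100000 nM. The three steps among them, a step that the two limits leave unreadable from compound 1 to compound 2, a step that the two limits leave unreadable from compound 1 to compound 3 and a step that the two limits leave unreadable from compound 2 to compound 3, are therefore not readable in size, because of the limit of > 100000 nM in this assay, at which 3 of the 3 values shown sit.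

Compound 4 `CCC(COc1c(Cl)cccc1Cl)OC(=O)NCc1ccccc1` differs from compound 3 in one place: 2,6-dichlorophenyl in place of 2,3-dichlorophenyl on an oxygen on a saturated carbon. Going by the values given here, nothing among the measured steps shows a readable movement for any change on this aromatic ring, so no step in this assay beyond the scatter is expected from compound 3 to compound 4, and the most likely outcome is again a limit. The estimate for compound 4 is 200000 nM, expected within 50000 nM to 1000000 nM, which corresponds to an expected step that the limit leaves unreadable from compound 3 to compound 4.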

Compound 4, half-maximal inhibitory concentration: > 100000 nM
Compound 4 gave a limit, no number; the forecaster's own chance of this, stated with the estimate: 85%; the middle value is on the limit's open side.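

In this assay compound 4 gives > 100000 nM, which is a limit and not a number. No step between compound 4 and compound 1, compound 2 or compound 3 can be read, for one reason: the limit of > 100000 nM in this assay, at which 4 of the 4 values shown sit. The compounds shown leave open whether any change to the shared core gives a measurable inhibition value.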